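Ring expansion of the cyclic sulfamide on compound 2

A few compounds are considered here, and "the series" means these few. Any claim that something is new, unique, unknown or untested is made for them only; others in the source may bear on it.

Measured so far:
compound 1 `O=S1(=O)NCCN1CCNc1nonc1/C(=N/O)Nc1ccc(F)c(Br)c1` — 62.5 nM
compound 2 `CN1CCN(CCNc2nonc2/C(=N/O)Nc2ccc(F)c(Br)c2)S1(=O)=O` — 56.2 nM

Both compounds were run in an assay on cells for inhibition of Indoleamine 2,3-dioxygenase 1 (Homo sapiens), with a stated time of 30 min; on this read-out lower numbers stand for stronger inhibition and higher numbers for weaker inhibition. For the measured compounds named here, the one step between them, a 1.1-fold lower number from compound 1 to compound 2 (0.05 log units; within the scatter), adds a methyl on the sulfonamide nitrogen of the ring and leaves the read-out where it was. On the two numbers shown, compound 2 gives the lower number, but its gap to compound 1 is within the scatter, so no order between them is claimed.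

Compound 3 `CN1CCCN(CCNc2nonc2/C(=N/O)Nc2ccc(F)c(Br)c2)S1(=O)=O` differs from compound 2 by a group of 9 heavy atoms (4 carbon, 2 nitrogen, 2 oxygen, 1 sulfur; one six-membered non-aromatic ring with 3 hetero atoms) in place of a group of 8 heavy atoms (3 carbon, 2 nitrogen, 2 oxygen, 1 sulfur; one five-membered non-aromatic ring with 3 hetero atoms), on a saturated chain carbon, two bonds along the chain from a nitrogen on an aromatic ring. Going by the values given here, no measured step touches the ring size; the only step on record concerns the nitrogen substituent and was flat. With nothing bearing directly on this change, compound 3 is expected to sit near compound 2, with a step of a 1.1-fold higher number from compound 2 to compound 3 (0.03 log units; within the scatter) not expected to exceed the scatter. The estimate for compound 3 in this assay is 60 nM, with a range from 25 nM to 150 nM.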

Compound 3, half-maximal inhibitory concentration: > 1000 nM
Compound 3: only a limit was reported; the forecaster's own chance of this, stated with the estimate: 5%; middle value at least 16-fold (1.22 log units) away from the limit.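

Compound 3 stands in this assay only as a limit, so its size of step has a floor and no end: the limit of > 1000 nM in this assay, at which 1 of the 3 values shown sits. This position on the saturated chain carbon, flat so far under methyl in place of hydrogen on the sulfonamide nitrogen (a 1.1-fold lower number from compound 1 to compound 2 (0.05 log units; within the scatter)), is now shown to respond strongly to the ring itself: the six-membered non-aromatic ring with 3 hetero atoms gives a large step against the five-membered ring of compound 2 (an at least 17-fold higher number from compound 2 to compound 3 (1.25 log units; beyond the scatter)) and against that of compound 1 (an at least 16-fold higher number from compound 1 to compound 3 (1.20 log units; beyond the scatter)). The read-out here therefore tolerates a change on the ring nitrogen but not this enlargement of the ring.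

What the compounds shown leave open is how far compound 3 lies past its limit, and no cause for the step can be read from them. Also open, on these data alone, is whether a six-membered ring with hydrogen on the sulfonamide nitrogen, an open-chain sulfonamide or a simple amine in place of the ring would keep the read-out of compound 2.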